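The compounds below may be only part of what the source reports. "The series", "measured", "known", "first", "only" and "open" are said of these compounds alone.

Compound 3 `CC1=CCC[C@H]2[C@](C)(CC3=CC(=O)C=C(N[C@@H](C(=O)O)C(C)C)C3=O)[C@@H](C)CC[C@]12C` and compound 1 `CC1=CCC[C@H]2[C@](C)(CC3=CC(=O)C=C(NCC(=O)O)C3=O)[C@@H](C)CC[C@]12C` share one core and differ in a single place: hydrogen in place of isopropyl on a saturated chain carbon bound to an amine nitrogen and a carbonyl carbon. In an ADME assay on MRC5 cells (Homo sapiens) for cytotoxicity, read by MTT assay, with a stated time of 72 h (on this read-out higher numbers stand for weaker inhibition and lower numbers for stronger inhibition), compound 3 gives 85400 nM, and the change to compound 1 made a step of a 2.1-fold higher number from compound 3 to compound 1 (0.33 log units; beyond the scatter), so that compound 1 gives 183000 nM. Compound 2 `CC(C)C[C@H](NC1=CC(=O)C=C(C(C)(C)C)C1=O)C(=O)O` is built on a different core, and the difference between the two cores is not broken down here. In this assay compound 2 reaches only > 200000 nM, which is a limit of the assay rather than a number. Compound 4 `C[C@H](NC1=CC(=O)C=C(C(C)(C)C)C1=O)C(=O)O` is reached from compound 2 by the same kind of change, (hydrogen in place of isopropyl on a saturated chain carbon, two bonds along the chain from an amine nitrogen and a carbonyl carbon), although the place is not identical: in compound 3 the carbon carrying the change is bound to an amine nitrogen and a carbonyl carbon, whereas in compound 2 it lies two bonds along the chain from them. The earlier step of a 2.1-fold higher number from compound 3 to compound 1 (0.33 log units; beyond the scatter) moved the number higher, and compound 2 already sits at the limit of > 200000 nM in this assay, at which 1 of the 3 values shown sits. Compound 4 is therefore expected to show a step that the limit leaves unreadable from compound 2 to compound 4, most likely reported again only as a limit. The estimated value for compound 4 in this assay is 250000 nM, between 150000 nM and 500000 nM.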

Compound 4, half-maximal inhibitory concentration: > 200000 nM
Compound 4: only a limit was reported; the forecaster's own chance of this, stated with the estimate: 85%; the middle value is on the limit's open side.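

No step can be read from compound 2 to compound 4 in this assay, because both compounds are reported only as a limit of the assay and not as a number: the limit of > 200000 nM in this assay, at which 2 of the 4 values shown sit.

The compounds shown leave open whether replacing isopropyl with hydrogen on the core of compound 2 changes the cytotoxicity at all, and what number either compound would give.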